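Azole exchange at the sulfonyl sulfur: compound 3 to compound 4

The source may report more compounds than this note shows. Statements on the series, on what has been measured and on what is new or still open speak of the compounds shown alone.

Of the compounds shown here, three have been measured in an assay on JAR cells for inhibition of sodium- and chloride-dependent glycine transporter 1 (Homo sapiens), read by scintillation counting, with a stated time of 3 h; a lower number here means a stronger inhibitor, a higher number a weaker inhibitor. Compound 1 `Cn1nncc1S(=O)(=O)N1CC(CNC(=O)c2ccc(Cl)cc2Cl)(CC2CC2)C1` gives 185 nM, compound 2 `Cn1ncc(S(=O)(=O)N2CC(CNC(=O)c3ccc(Cl)cc3Cl)(CC3CC3)C2)n1` gives 132 nM, and compound 3 `Cn1ncnc1S(=O)(=O)N1CCC(CNC(=O)c2ccc(Cl)cc2Cl)(CC2CC2)CC1` gives 314 nM. Compound 3 carries the highest number of the three, although its gap to compound 1 is within the scatter; only its gap to compound 2 lies beyond it. For the measured compounds named here, the single step measured between neighbours that differ in one place is a 1.4-fold lower number from compound 1 to compound 2 (0.15 log units; within the scatter), an exchange of one azole for another on a sulfonyl sulfur, and it stays within the scatter.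

Compound 4 `Cn1cc(S(=O)(=O)N2CCC(CNC(=O)c3ccc(Cl)cc3Cl)(CC3CC3)CC2)cn1` differs from compound 3 in one place: 1-methyl-1H-pyrazol-4-yl in place of 1-methyl-1H-1,2,4-triazol-5-yl on a sulfonyl sulfur. Going by the values given here, no measured pair tests this exact exchange on the core of compound 3. Among the compounds with values here, the only evidence on swapping the azole at the sulfonyl sulfur is the step from compound 1 to compound 2, which changed the number little, so a step of similar small size is expected for compound 4 in this assay, a 1.0-fold lower number from compound 3 to compound 4 (0.02 log units; within the scatter), in no direction beyond the scatter. Compound 4 is accordingly estimated at 300 nM, with a range from 120 nM to 750 nM in this assay.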

Compound 4, half-maximal inhibitory concentration: 10.4 nM
Compound 4: middle estimate off by 29-fold (1.46 log units), on the high side, outside the stated range (below it).
By their numbers in this assay, from the lowest: compound 4; then compounds 2, 1 and 3 (each within the scatter of the next, the first and the last beyond it).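

In this assay, the azole on the sulfonyl sulfur proves able to move the number strongly: the exchange gives a 30-fold lower number from compound 3 to compound 4 (1.48 log units; beyond the scatter), whereas the earlier azole exchange gave a 1.4-fold lower number from compound 1 to compound 2 (0.15 log units; within the scatter). The size of a step at this position therefore depends on the exchange or on the core carrying it, and the change here alters the ring from 3 hetero atoms to 2, and the hydrogen-bond acceptors from 3 to 2, while also replacing a 1,2,4-triazol-5-yl attachment with a pyrazol-4-yl attachment, all in a single step. No measurement at hand accounts for the large step.

Open, going by these compounds, is whether 1-methyl-1H-pyrazol-4-yl gives a step of similar size on the core of compound 1, or whether the large step belongs to the core of compound 3 alone. Also open, on these data alone, is how far the position tolerates departure from the methyl azoles, for instance a phenyl group, an ethyl chain or a pyrazole bearing a longer chain in place of the methyl.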